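Working notes: acetyl to isopropylcarbamoyl, metabolic stability

A few compounds are considered here, and "the series" means these few. Any claim that something is new, unique, unknown or untested is made for them only; others in the source may bear on it.

Compound 1 `COc1ccc(-c2c(C)nc3c(N4CC[C@@H](NC(C)=O)C4)cc(C)nn23)cc1OC` is run in an ADME assay on microsomes from liver (Homo sapiens) for metabolic stability, read by LC-MS, with NADPH named in the record, with a stated time of 60 min, tested at 1 uM, in the absence of a further agent; a lower number here means that less of the compound is left, a higher number that more of the compound is left. Compound 1 returns only a limit of the assay there, > 95%. Compound 2 `CC(=O)N[C@@H]1CCN(c2cc(C)nn3c(-c4ccccc4)c(C)nc23)C1` likewise gives a limit in this assay, > 95%. Compound 3 `CC(=O)N[C@@H]1CCN(c2cc(C)nn3c(-c4ccco4)c(C)nc23)C1` also sits at a limit in this assay, > 95%. The steps a step that the two limits leave unreadable from compound 1 to compound 2, a step that the two limits leave unreadable from compound 1 to compound 3 and a step that the two limits leave unreadable from compound 2 to compound 3 therefore have no readable size, because of the limit of > 95% in this assay, at which 3 of the 3 values shown sit. Within the data shown here, compound 4 `COc1ccc(-c2c(C)nc3c(N4CC[C@@H](NC(=O)NC(C)C)C4)cc(C)nn23)cc1OC` differs from compound 1 by isopropylamino in place of methyl on a carbonyl carbon; none of the measured steps changes anything on that carbonyl carbon, so none bears directly on it. With every shown value at the limit, compound 4 is expected to stay at the limit as well, a step of a number no higher from compound 1 to compound 4 (the limit leaves the size open) in this assay. The estimate for compound 4 in this assay is 95%, expected between 85% and 99%.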

Compound 4, percent of the compound remaining: > 95%
Compound 4: no number, only a limit (the forecaster's own chance of this, stated with the estimate: 70%); the middle value lies on the limit itself.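

No size can be read for the step between compound 1 and compound 4 in this assay, because both sit at a limit of the assay: the limit of > 95% in this assay, at which 4 of the 4 values shown sit.

The compounds shown leave open whether isopropylamino in place of methyl on the carbonyl carbon changes the amount of compound left at all.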